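The source may hold more compounds than are shown below. What is called first, only, known or untested is meant among the compounds shown, and "the series" means these compounds.

Measured so far:
compound 1, `CC(=O)SCCC(CCCCC(=O)O)SC(C)=O` — in a functional assay on HO8910 cells (Homo sapiens) for inhibition, read by MTT assay, with a stated time of 24 h, tested at 100 ug/mL (on this read-out lower numbers stand for less inhibition of growth and higher numbers for more inhibition of growth at the one concentration tested), compound 1 is recorded as "not active" (no number reported).
compound 2, `O=C(CCCCC(S)CCS)Nc1ccc(Cl)cc1` — in this assay compound 2 gives 21.3%.

Compound 1 stands at the bottom of what is shown: for compound 1 the outcome in this assay is only the word "not active" (no number reported), with no number behind it, so its position can only be described as no measurable inhibition of growth at the one concentration tested. Within the data shown here, compound 2, the only compound with a number, shows a modest degree of inhibition.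

The step to compound 3, `CC(=O)SCCC(CCCCC(=O)Nc1ccccc1Cl)SC(C)=O`, changes one place in compound 1: (2-chlorophenyl)amino in place of hydroxy on a carbonyl carbon. Among the measured compounds shown here, no measured pair shows the effect of this change, so the expectation rests on the two values alone. A small upward step in this assay, at most a little beyond the scatter, seems plausible because compound 1 is recorded as "not active" (no number reported) and cannot fall lower. Compound 3 is therefore expected to give about 15%, estimated to lie between 0% and 35%.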

Compound 3, percent growth inhibition at one concentration: "not active" (no number reported)
Nothing numeric was reported for compound 3, so the estimate cannot be set against anything.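

In this assay, among these compounds, compound 1 gives "not active" (no number reported) and compound 3 gives "not active" (no number reported) as well, so no step between them can be read. Nothing shown offers an explanation for this result. On these data alone, whether (2-chlorophenyl)amino in place of hydroxy changes growth inhibition at all remains open.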